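Methoxy for trifluoromethyl: notes toward compound 3

The compounds below may be only part of what the source reports. "The series", "measured", "known", "first", "only" and "open" are said of these compounds alone.

Of the compounds shown here, two have been measured in a functional assay on CHO cells for agonist activity at Free fatty acid receptor 1 (Homo sapiens), read by reporter gene assay; on this read-out lower numbers stand for smaller maximal responses and higher numbers for larger maximal responses. Compound 1 `O=C(O)CCc1ccc(NCc2ccc(C(F)(F)F)cc2)cc1` gives 133% in this assay. Compound 2 `O=C(O)CCc1ccc(NCc2ccccc2Cl)cc1` gives 122% in this assay. Compound 1 thus stands highest of the two numbers, and its nearest neighbour, compound 2, lies lower by an amount beyond the usual scatter of this read-out.

Compound 3 `COc1ccc(CNc2ccc(CCC(=O)O)cc2)cc1` has not yet been measured in this assay. It differs from compound 1 in one place: methoxy in place of trifluoromethyl on an aromatic carbon. Within the data shown here, no step between two measured compounds touches this position, so nothing measured so far tells how the largest response moves when methoxy replaces trifluoromethyl on an aromatic carbon. Among the measured compounds shown here, both measured compounds give responses at or above the reference, and that level is the only anchor for compound 3.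

The working expectation is a small step downward from compound 1, near the edge of the scatter, namely a number 13 percentage points lower from compound 1 to compound 3 (beyond the scatter). Compound 3 is accordingly estimated at 120% in this assay, with a range from 95% to 145%.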

Compound 3, largest response reached (reported as percent of maximum), in percent of the reference or control that the assay uses: 159%
The estimate for compound 3 lay 39 percentage points below the measured number; measured number outside the range, above it.
By their numbers in this assay, from the lowest: compound 2; then compound 1; then compound 3.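

In this assay, this position, an aromatic carbon para to a large group, now has its first measured step: methoxy in place of trifluoromethyl gives a number 26 percentage points higher from compound 1 to compound 3 (beyond the scatter). The response at this position therefore does not depend on keeping trifluoromethyl, since a group with fewer heavy atoms and one hydrogen-bond acceptor, the only acceptor difference counted between the two groups, is accompanied by the larger maximal response. This rests on a single pair of compounds, and nothing available on these compounds bears on why the response moves with this change.

As far as these compounds go, it remains open whether the rise is particular to methoxy or would also appear with other groups on this aromatic carbon, such as ethoxy, hydroxyl or an amine, and whether a response still larger than that of compound 3 can be reached here. From the compounds shown here alone, it also remains open whether the same exchange gives a step of similar direction and size on another carbon of this ring or on a core with a longer carboxylic acid chain.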